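A few compounds are considered here, and "the series" means these few. Any claim that something is new, unique, unknown or untested is made for them only; others in the source may bear on it.

Measured so far in a functional assay on the whole organism (strain Wistar) for inhibition, with Rattus norvegicus as the target, read by paw edema, with stated times of 60 min and 1 h, at a dose of 100 mg/kg by the oral route; on this read-out higher numbers stand for more inhibition at the one dose given (going by the name of the read-out) and lower numbers for less inhibition:
compound 1 `CCCCCNC(=O)CC1CCc2cc(OC)c(OC)cc21`: 34.4%
compound 2 `COc1cc2c(cc1OC)C(CC(=O)NC1CCCC1)CC2`: 40.6%
compound 3 `COc1cc2c(cc1OC)C(CC(=O)NCc1ccccc1)CC2`: 18.8%

Compound 3 stands lowest of the three, the gaps to compound 1 and to compound 2 both lying beyond the scatter, as the steps of a number 15.6 percentage points lower from compound 1 to compound 3 (beyond the scatter) and a number 21.8 percentage points lower from compound 2 to compound 3 (beyond the scatter) show; the step of a number 6.2 percentage points higher from compound 1 to compound 2 (within the scatter) is within the scatter.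

Compound 4 `COc1cc2c(cc1OC)C(CC(=O)N1CCOCC1)CC2` carries morpholin-4-yl in place of benzylamino on a carbonyl carbon. The two steps into compound 3 both exchanged a pentyl or cyclopentyl for the benzyl and fell; compound 4 again takes the benzyl away, in favour of a saturated ring. Among the compounds with values here, no measured step, however, removes the hydrogen-bond donor, so the precedent is partial. A modest rise in this assay is expected, a number 13.2 percentage points higher from compound 3 to compound 4 (beyond the scatter). Compound 4 is estimated at 32%, range 18% to 46%.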

Compound 4, a percentage reported as inhibition, in the whole organism at one dose (the size of the read-out at that dose, not a potency): 15.6%
Compound 4: middle estimate off by 16.4 percentage points, on the high side; measured number below the stated range.
By their numbers in this assay, from the lowest: compounds 4 and 3 (each within the scatter of the next); then compounds 1 and 2 (each within the scatter of the next).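

In this assay, morpholin-4-yl in place of benzylamino on the carbonyl carbon gives no recovery (a number 3.2 percentage points lower from compound 3 to compound 4 (within the scatter)), so losing the aromatic ring and the amide hydrogen together leaves compound 4 level with compound 3. A saturated ring here does not match pentylamino (a number 18.8 percentage points lower from compound 1 to compound 4 (beyond the scatter)) or cyclopentylamino (a number 25 percentage points lower from compound 2 to compound 4 (beyond the scatter)), so a saturated ring alone does not secure the higher numbers. No evidence on hand accounts for this result.

As far as these compounds go, whether the low number of compound 4 goes with the missing amide hydrogen or with the ring oxygen stays open. Piperidin-1-yl on the same carbonyl carbon would separate the two.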